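The source may hold more compounds than are shown below. What is called first, only, known or untested is meant among the compounds shown, and "the series" means these compounds.

Three compounds have been measured in an assay on HEK293 cells for displacement of a labelled ligand from NPC1-like intracellular cholesterol transporter 1 (Homo sapiens); a lower number here means a stronger inhibitor, a higher number a weaker inhibitor:

Compound 1 `CC(C)(C)c1ccc(C(=O)N2CCC3(CC2)C(=O)N(CC(=O)NCCCN)CN3c2ccccc2)cc1` gives 4200 nM
Compound 2 `CC(C)(C)c1ccc(C(=O)N2CCC3(CC2)C(=O)N(CC(=O)NCCCCCNS(C)(=O)=O)CN3c2ccccc2)cc1` gives 5500 nM
Compound 3 `CC(C)(C)c1ccc(C(=O)N2CCC3(CC2)C(=O)N(CC(=O)N2CCCC(O)C2)CN3c2ccccc2)cc1` gives 12200 nM

All three share the same core and differ only in the group on the carbonyl carbon at the end of the short side chain. Compound 3 has the highest number of the three: the step of a 2.9-fold higher number from compound 1 to compound 3 (0.46 log units; beyond the scatter) and the step of a 2.2-fold higher number from compound 2 to compound 3 (0.35 log units; beyond the scatter) both lie beyond the scatter, though only modestly, while the step of a 1.3-fold higher number from compound 1 to compound 2 (0.12 log units; within the scatter) stays within it. So moving from an open chain amine on that carbonyl to the 3-hydroxypiperidin-1-yl ring of compound 3 raised the number somewhat.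

Compound 4 `CC(C)(C)c1ccc(C(=O)N2CCC3(CC2)C(=O)N(CC(=O)N2CCCCC2CO)CN3c2ccccc2)cc1` is the next step: 2-(hydroxymethyl)piperidin-1-yl in place of 3-hydroxypiperidin-1-yl on a carbonyl carbon. The ring stays a six-membered saturated ring with one nitrogen, and the single hydroxyl donor stays, but it now sits on a one-carbon arm from the ring rather than on the ring itself. Among the compounds with values here, none of the measured steps probes this kind of shift within the ring, so there is nothing to argue for a move in either direction. The estimate for compound 4 is therefore a step of a 1.0-fold lower number from compound 3 to compound 4 (0.01 log units; within the scatter) that stays within the scatter, giving an expected value of 12000 nM with a range from 4000 nM to 36000 nM.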

Compound 4, half-maximal inhibitory concentration: 11800 nM
Beside the measured number, compound 4's estimate is 1.0-fold (0.01 log units) above it; measured number inside the range.
By their numbers in this assay, from the lowest: compounds 1 and 2 (each within the scatter of the next); then compounds 4 and 3 (each within the scatter of the next).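

In this assay, exchanging 3-hydroxypiperidin-1-yl for 2-(hydroxymethyl)piperidin-1-yl on this carbonyl carbon adds one carbon while keeping one six-membered ring and one hydroxyl, and the outcome cannot be told apart from the scatter (a 1.0-fold lower number from compound 3 to compound 4 (0.01 log units; within the scatter)). The gap first seen with compound 3 also appears with this second ring, with modest steps beyond the scatter both (a 2.1-fold higher number from compound 2 to compound 4 (0.33 log units; beyond the scatter)) and (a 2.8-fold higher number from compound 1 to compound 4 (0.45 log units; beyond the scatter)), so among these four compounds both ring amides have higher numbers than both open-chain amides, and no compound goes against this. No measurement shown here explains either the flat step between the two rings or the gap to the open chains.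

Going by these compounds, what stays open is whether that gap follows the ring or the hydroxyl, a question that plain piperidin-1-yl, with the ring but no hydroxyl, could help separate. A 2-hydroxyethylamino group, with a hydroxyl on an open chain, could test the same question from the other side.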